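A few compounds are considered here, and "the series" means these few. Any claim that something is new, unique, unknown or untested is made for them only; others in the source may bear on it.

For the measured compounds named here, in an ADME assay on the whole organism (Mus musculus, strain CD1) for pharmacokinetics, with a stated time of 6 h, at a dose of 10 mg/kg by the oral route (on this read-out higher numbers stand for higher exposure at the dose given and lower numbers for lower exposure), compound 1 (`Cc1ccc(-c2cnc(C[C@H]3CCNC3)nc2-c2ccc(C#N)cc2)cc1`) gives 354 ng.h/mL, the lower of the two numbers so far, and compound 2 (`Cc1ccc(-c2c(-c3ccc(C#N)cc3)nc(N3CCC(N)CC3)c(=O)n2C)cc1`) gives 2920 ng.h/mL, a gap beyond the scatter, though these two differ in more than one place. Compound 3 (`Cc1ccc(-c2cnc(N3CC[C@@H]4NCC[C@@H]4C3)nc2-c2ccc(C#N)cc2)cc1`) keeps the core of compound 1 and changes the group on the aromatic carbon between two ring nitrogen atoms: a group of 9 heavy atoms (7 carbon, 2 nitrogen; one five-membered non-aromatic ring with 1 hetero atom, one six-membered non-aromatic ring with 1 hetero atom) in place of a group of 6 heavy atoms (5 carbon, 1 nitrogen; one five-membered non-aromatic ring with 1 hetero atom), on an aromatic carbon. Going by the values given here, no single-place step has been measured in this assay. Compound 2, at 2920 ng.h/mL, shows room upward. A moderate rise is expected, a 2.3-fold higher number from compound 1 to compound 3 (0.35 log units; beyond the scatter). Compound 3 is estimated at 800 ng.h/mL, with an expected range of 200 ng.h/mL to 3000 ng.h/mL.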

Compound 3, area under the concentration-time curve: 5730 ng.h/mL
Compound 3: middle estimate off by 7.2-fold (0.86 log units), on the low side; measured number outside the range, above it.
By their numbers in this assay, from the lowest: compound 1; then compounds 2 and 3 (each within the scatter of the next).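

In this assay, the position on the aromatic carbon between two ring nitrogen atoms proves highly responsive on the shared core: replacing (pyrrolidin-3-yl)methyl with the group of 9 heavy atoms gives a 16-fold higher number from compound 1 to compound 3 (1.21 log units; beyond the scatter). The two groups differ in size, ring count and defined stereocentres, so this one step cannot separate those features. No measurement available here accounts for the rise. Open, going by these compounds, is whether the second ring is needed, and how a piperazine or an open-chain amine would read at this position.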